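Bromo for chloro: a small step on a shared core

The source may hold more compounds than are shown below. What is called first, only, known or untested is meant among the compounds shown, and "the series" means these compounds.

Measured so far:
Compound 1 `CC(c1ccc(-c2ccccc2)c(F)c1)c1nnc2n1N=C(c1ccc(C(F)(F)F)cc1)CS2`: 6100 nM
Compound 2 `COc1ccc(C2=Nn3c(nnc3C(C)c3ccc(-c4ccccc4)c(F)c3)SC2)cc1`: 4400 nM
Compound 3 `CC(c1ccc(-c2ccccc2)c(F)c1)c1nnc2n1N=C(c1ccc(Cl)cc1)CS2`: 7800 nM

In a functional assay on HCT-116 cells (Homo sapiens) for inhibition, read by sulforhodamine B assay, with a stated time of 72 h (on this read-out lower numbers stand for stronger inhibition and higher numbers for weaker inhibition), compound 3 gives 7800 nM. That is the largest of the three numbers, yet the step of a 1.3-fold higher number from compound 1 to compound 3 (0.11 log units; within the scatter) and the step of a 1.8-fold higher number from compound 2 to compound 3 (0.25 log units; within the scatter) both stay within the scatter, so the three compounds cannot be told apart on this read-out.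

Compound 4 `CC(c1ccc(-c2ccccc2)c(F)c1)c1nnc2n1N=C(c1ccc(Br)cc1)CS2` differs from compound 3 only in one group: bromo in place of chloro on an aromatic carbon. Among the measured compounds shown here, the steps that bear on this change are the earlier swaps of the group at the same place, namely a 1.4-fold lower number from compound 1 to compound 2 (0.14 log units; within the scatter), a 1.3-fold higher number from compound 1 to compound 3 (0.11 log units; within the scatter) and a 1.8-fold higher number from compound 2 to compound 3 (0.25 log units; within the scatter). None of them moved the number beyond the scatter, whether the group was trifluoromethyl, methoxy or chloro. A bromo group in the same place is therefore expected to behave no differently, and no step beyond the scatter is expected in this assay in either direction.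

On that basis compound 4 is estimated at 7000 nM, with a range from 3500 nM to 14000 nM, which amounts to an expected step of a 1.1-fold lower number from compound 3 to compound 4 (0.05 log units; within the scatter).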

Compound 4, half-maximal inhibitory concentration: 7100 nM
Compound 4: middle estimate off by 1.0-fold (0.01 log units), on the low side; low and high end bracket the measured number.
By their numbers in this assay, from the lowest: compounds 2, 1, 4 and 3 (each within the scatter of the next).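

In this assay, the change from 4-chlorophenyl to 4-bromophenyl gives a 1.1-fold lower number from compound 3 to compound 4 (0.04 log units; within the scatter), and setting bromo against the other two groups at this place gives a 1.6-fold higher number from compound 2 to compound 4 (0.21 log units; within the scatter) and a 1.2-fold higher number from compound 1 to compound 4 (0.07 log units; within the scatter). With bromo added, the series at this place on the shared core now holds four groups, trifluoromethyl, methoxy, chloro and bromo, and every step among them stays within the scatter, so this read-out separates none of the four compounds and the second halogen opens no gap from the first. Nothing measured here accounts for this flat response or ties it to any property of these groups.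

The compounds shown leave open whether the same flat response would hold for an amine, a carboxylic acid or a longer chain such as butyl at this place, where a step beyond the scatter might still appear. They also leave open whether the number in this assay would move for a change made elsewhere on the shared core, as all four compounds differ only at this one place.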